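The source may hold more compounds than are shown below. What is called first, only, known or untested is meant among the compounds shown, and "the series" means these compounds.

Compound 1 `CC(O)(CS(=O)(=O)c1ccc(Cl)cc1)c1nc(-c2ccc(Cl)cc2)no1` gives > 100000 nM in a functional assay on DU-145 cells (Homo sapiens) for cytotoxicity, read by MTT assay (on this read-out lower numbers stand for stronger inhibition and higher numbers for weaker inhibition), which is a limit of the assay and not a number. Compound 2 `CC(O)(CSc1ccc(Cl)cc1)c1nc(-c2ccc(F)c(Cl)c2)no1` gives 500 nM. Compound 3 `CC(O)(CS(=O)(=O)c1ccc(Cl)cc1)c1nc(-c2ccc(F)c(Cl)c2)no1` gives 35500 nM.

Compound 1 and compound 3 share one core and differ in a single ring: 4-chlorophenyl in place of 3-chloro-4-fluorophenyl on an aromatic carbon. This change gives an at least 2.8-fold higher number from compound 3 to compound 1 (0.44 log units; beyond the scatter); since compound 1 sits at the limit of > 100000 nM in this assay, at which 1 of the 3 values shown sits, only a lower bound on the step is known. Compound 2 has another core than compound 3; the difference between the two cores is not broken down here.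

Compound 4 `CC(O)(CSc1ccc(Cl)cc1)c1nc(-c2ccc(Cl)cc2)no1` has not yet been measured. It stands to compound 2 as compound 1 stands to compound 3, the same change at the same place: 4-chlorophenyl in place of 3-chloro-4-fluorophenyl on an aromatic carbon. A step of a 3.0-fold higher number from compound 2 to compound 4 (0.48 log units; beyond the scatter) is expected, because the same change earlier gave an at least 2.8-fold higher number from compound 3 to compound 1 (0.44 log units; beyond the scatter). For compound 4 the estimated value in this assay is 1500 nM, most likely between 400 nM and 8000 nM.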

Compound 4, half-maximal inhibitory concentration: 14500 nM
Estimate against measurement, compound 4: 9.7-fold (0.99 log units) below; measured number outside the range, above it.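

In this assay, replacing 3-chloro-4-fluorophenyl with 4-chlorophenyl on the core of compound 2 gives a clearly weaker result: a 29-fold higher number from compound 2 to compound 4 (1.46 log units; beyond the scatter). Both cores move in the same direction, but this does not establish that the change has the same size on each: the same change on two cores in this assay, an at least 2.8-fold higher number (0.44 log units; beyond the scatter) from compound 3 to compound 1 and a 29-fold higher number (1.46 log units; beyond the scatter) from compound 2 to compound 4; the limit leaves it open whether they differ. The value of compound 1, > 100000 nM, is a limit of the assay and not a number.

The compounds shown leave open what a phenyl ring carrying only fluorine, or a plain phenyl ring, would give at this place, so the separate contributions of the fluorine and chlorine atoms remain unresolved. They also leave open whether the same direction would hold on a third core.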